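The source may hold more compounds than are shown below. What is called first, only, known or untested is meant among the compounds shown, and "the series" means these compounds.

Among the compounds with values here, three related compounds have been tested so far in a functional assay on HGC-27 cells (Homo sapiens) for inhibition, read by MTT assay, with a stated time of 72 h (on this read-out lower numbers stand for stronger inhibition and higher numbers for weaker inhibition), and only one gave a true number. Compound 1 `C[C@@H]1CCN(c2cc(-c3ccccc3)nc3ncnn23)C[C@@H]1N(C)c1ncnc2[nH]ccc12` reads > 100000 nM there, which is a limit of the assay and not a number. Compound 3 `Cc1nc2nc(SCc3ccc(Cl)cc3)nn2c(N2CC[C@@H](C)[C@@H](N(C)c3ncnc4[nH]ccc34)C2)c1C` reads > 100000 nM there, which is likewise a limit and not a number. Within the data shown here, compound 2 `Cc1cc(N2CC[C@@H](C)[C@@H](N(C)c3ncnc4[nH]ccc34)C2)n2nc(SCc3ccccc3Br)nc2n1` gives 21300 nM as the only actual number in the set. The rest of the data hold only the limit of > 100000 nM in this assay, at which 2 of the 3 values shown sit, and no number.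

Compound 4 `Cc1cc(N2CC[C@@H](C)[C@@H](N(C)c3ncnc4[nH]ccc34)C2)n2nc(SCC3CCCCC3)nc2n1` has not yet been measured. The change from compound 2 is cyclohexyl in place of 2-bromophenyl on a saturated chain carbon bound to a sulfur and, in short, cyclohexyl stands in place of 2-bromophenyl on a saturated chain carbon bound to a sulfur. Among the measured compounds shown here, no two measured compounds differ in one place only, so no measured step sets the size here. With compound 2 at 21300 nM in this assay as the sole reference, a small move toward weaker inhibition seems likeliest, though a result within the usual scatter is also possible. The expected step of a 1.4-fold higher number from compound 2 to compound 4 (0.15 log units; within the scatter) is an estimate and a modest one. For compound 4 the estimated value is 30000 nM with an expected range from 10000 nM to 90000 nM on this read-out.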

Compound 4, half-maximal inhibitory concentration: 11500 nM
Compound 4: middle estimate off by 2.6-fold (0.42 log units), on the high side; the measured number falls inside the stated range.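

In this assay, within the data shown here, putting cyclohexyl in place of 2-bromophenyl on a saturated chain carbon bound to a sulfur gives a 1.9-fold lower number from compound 2 to compound 4 (0.27 log units; within the scatter), the first step in this set that can be read between two true numbers. This position therefore tolerates the loss of both the aromatic ring and the bromine with no change beyond the usual scatter, so a non-aromatic ring of carbon only serves as well here as the 2-bromophenyl group of compound 2. Compound 2 and compound 4 are the only pair that can be compared, and the other steps cannot be read, so this finding rests on one step, with the remaining values being limits and not numbers: the limit of > 100000 nM in this assay, at which 2 of the 4 values shown sit.

This single step changes the ring type and removes the bromine at once, so it cannot show what each change does alone, and any opposing effects of the two would stay hidden. Also open, as far as these compounds go, is whether an amine, a carboxylic acid or a longer chain in place of cyclohexyl would still give a true number in this assay or would move it beyond the scatter.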